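Beta-lactam series: acetamidomethyl replacing 1-fluoroethyl

A few compounds are considered here, and "the series" means these few. Any claim that something is new, unique, unknown or untested is made for them only; others in the source may bear on it.

Three compounds sharing one fused core have numbers in an ADME assay, in phosphate buffer, at 28 degrees C, at pH 7.0; on this read-out lower numbers stand for a shorter-lived compound and higher numbers for a longer-lived compound. Compound 1 `CC(C)(C)C1=C(C(=O)O)N2C(=O)[C@H](CO)[C@H]2O1` carries hydroxymethyl on the saturated ring carbon and gives 5 h. Compound 2 `CC(C)(C)C1=C(C(=O)O)N2C(=O)[C@H]([C@@H](O)c3ccccc3)[C@@H]2O1`, with a hydroxy-phenyl-methyl arm at that position, gives 2.2 h. Compound 3 `C[C@H](F)[C@H]1C(=O)N2C(C(=O)O)=C(C(C)(C)C)O[C@H]12`, with 1-fluoroethyl there, gives 7.2 h. Compound 3 sits at the top of the three numbers, but the gap to compound 1 is within the scatter, while compound 2 lies beyond the scatter below it. Within the data shown here, the one measured step that touches this position is a 1.4-fold higher number from compound 1 to compound 3 (0.16 log units; within the scatter), so exchanging the group on this carbon has so far not moved this assay beyond its scatter, apart from the larger arm of compound 2, for which no single-change step is recorded.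

Compound 4 `CC(=O)NC[C@H]1C(=O)N2C(C(=O)O)=C(C(C)(C)C)O[C@H]12` is not yet measured. Its change from compound 3 is acetamidomethyl in place of 1-fluoroethyl on a saturated ring carbon. Among the measured compounds shown here, the only step that bears on it, from compound 1 to compound 3, was within the scatter, and the hydroxymethyl of compound 1 shares a donor and acceptor count with the incoming group. A step of a 1.4-fold lower number from compound 3 to compound 4 (0.16 log units; within the scatter) is therefore expected, not beyond the scatter. Compound 4 is estimated at 5 h, within 2.5 h to 10 h.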

Compound 4, half-life: < 3 h
Compound 4: no number, only a limit (the forecaster's own chance of this, stated with the estimate: 5%); middle value at least 1.6-fold (0.22 log units) away from the limit.
By their numbers in this assay, from the lowest: compound 2; then compounds 1 and 3 (each within the scatter of the next).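

In this assay compound 4 is a limit and not a number: the limit of < 3 h in this assay, at which 1 of the 4 values shown sits.

Even read only as a floor, the exchange on this saturated ring carbon gives an at least 2.4-fold lower number from compound 3 to compound 4 (0.38 log units; beyond the scatter), the first single-change step at this position that lies beyond the scatter, so this carbon does not tolerate every group equally in this read-out. Against the hydroxymethyl arm the reading is less firm: acetamido in place of hydroxy on the saturated chain carbon gives an at least 1.6-fold lower number from compound 1 to compound 4 (0.22 log units; that floor lies within the scatter), which leaves it unsettled whether acetamidomethyl and hydroxymethyl truly differ here.

The limit also leaves the full size of both steps open, as the distance of compound 4 from the other compounds has only a floor. From the compounds shown here alone, whether the shift follows the acetamido group itself or simply the longer arm also stays open, and an aminomethyl, a carboxylic acid or a plain propyl chain on this carbon would be the comparisons that could separate the two readings.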